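Compound 3 to compound 4: vinyl for prop-1-yn-1-yl

A few compounds are considered here, and "the series" means these few. Any claim that something is new, unique, unknown or untested is made for them only; others in the source may bear on it.

compound 1 `Cc1cc2c(C(N)=O)cccc2n1-c1nc2c(c(NCc3ccccc3)n1)COCC2` gives 146 nM
compound 2 `C#CC(=O)Nc1cccc2c1cc(C)n2-c1nc2c(c(NCc3ccccc3)n1)COCC2` gives 78.7 nM
compound 3 `CC#CC(=O)Nc1cccc2c1cc(C)n2-c1nc2c(c(NCc3ccccc3)n1)COCC2` gives 600 nM

In a functional assay on MIA PaCa-2 cells (Homo sapiens) for antiproliferative activity (on this read-out higher numbers stand for an effect only at larger amounts of compound and lower numbers for an effect already at smaller amounts), compound 3 stands at 600 nM, the highest number of the three. Compound 4 `C=CC(=O)Nc1cccc2c1cc(C)n2-c1nc2c(c(NCc3ccccc3)n1)COCC2` carries vinyl in place of prop-1-yn-1-yl on a carbonyl carbon. Among the measured compounds shown here, no measured compound carries vinyl, so the evidence is indirect. The nearest measured change is methyl in place of hydrogen on a triple-bonded carbon (a 7.6-fold higher number from compound 2 to compound 3 (0.88 log units; beyond the scatter)), a modest step. The other steps are (a 4.1-fold higher number from compound 1 to compound 3 (0.61 log units; beyond the scatter)), also modest, and (a 1.9-fold lower number from compound 1 to compound 2 (0.27 log units; within the scatter)), which stays within the scatter. For the measured compounds named here, compound 3 is thus the one compound apart from the other two, and compound 4, like compound 2 at 78.7 nM, has no methyl on its unsaturated end. A modest step towards a lower number is therefore expected in this assay, with the expected size being (a 5.5-fold lower number from compound 3 to compound 4 (0.74 log units; beyond the scatter)). For compound 4 the estimated value is 110 nM, with an expected range of 35 nM to 350 nM.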

Compound 4, half-maximal effective concentration: 880 nM
The estimate for compound 4 lay 8.0-fold (0.90 log units) below the measured number, outside the stated range (above it).
By their numbers in this assay, from the lowest: compounds 2 and 1 (each within the scatter of the next); then compounds 3 and 4 (each within the scatter of the next).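

In this assay, vinyl on the carbonyl carbon groups with prop-1-yn-1-yl and not with ethynyl: a 1.5-fold higher number from compound 3 to compound 4 (0.17 log units; within the scatter) stays within the scatter, while an 11-fold higher number from compound 2 to compound 4 (1.05 log units; beyond the scatter) is large and a 6.0-fold higher number from compound 1 to compound 4 (0.78 log units; beyond the scatter) is modest. The absence of a methyl on the unsaturated end therefore does not by itself put a compound alongside compound 2, and of the three acylamino compounds only compound 2 lies within the scatter of compound 1. Nothing measured here explains why ethynyl stands apart from vinyl and prop-1-yn-1-yl.

Open, as far as these compounds go, is whether a methyl on the vinyl end, as in prop-1-en-1-yl, would shift the number as it does on ethynyl. Also open, from the compounds shown here alone, is where a saturated ethyl group on the carbonyl carbon, or a vinyl group bearing a dimethylaminomethyl chain, would fall.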